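The source may hold more compounds than are shown below. What is called first, only, known or untested is meant among the compounds shown, and "the series" means these compounds.

Working notes on the series. Compound 1 `O[C@H](COCCOC[C@@H](O)Cc1c[nH]nn1)Cc1ccc(-c2ccccc2)cc1` carries only hydrogen on the aromatic nitrogen of its five-membered ring. In a functional assay on HCT-116 cells (Homo sapiens) for inhibition, read by MTT assay, with a stated time of 72 h (a lower number here means a stronger inhibitor of growth, a higher number a weaker inhibitor of growth), compound 1 reaches the assay limit, > 100000 nM. Going by the values given here, compound 2 `O[C@H](COCCOC[C@@H](O)Cc1cn(-c2ccc3c(c2)OCCO3)nn1)Cc1ccc(-c2ccccc2)cc1` places a 2,3-dihydro-1,4-benzodioxin-6-yl group on that nitrogen; in this assay compound 2 gives 16500 nM, the only true number so far. The value of compound 1 is a limit (the limit of > 100000 nM in this assay, at which 1 of the 2 values shown sits). The step of an at least 6.0-fold lower number from compound 1 to compound 2 (0.78 log units; beyond the scatter) shows that a substituent on this nitrogen matters. Compound 3 `N#Cc1ccc(Cn2cc(C[C@H](O)COCCOC[C@@H](O)Cc3ccc(-c4ccccc4)cc3)nn2)cc1` differs from compound 2 by 4-cyanobenzyl in place of 2,3-dihydro-1,4-benzodioxin-6-yl on an aromatic nitrogen. Among the compounds with values here, no measured step tests one aryl group against another here, so compound 3 is expected to stay near compound 2, a 1.2-fold higher number from compound 2 to compound 3 (0.08 log units; within the scatter), with an estimate for compound 3 of 20000 nM (5000 nM to 80000 nM).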

Compound 3, concentration for 50% growth inhibition: 8800 nM
Beside the measured number, compound 3's estimate is 2.3-fold (0.36 log units) above it; measured number inside the range.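

With 4-cyanobenzyl on this aromatic nitrogen, the result stays within the scatter of the 2,3-dihydro-1,4-benzodioxin-6-yl group in this assay: a 1.9-fold lower number from compound 2 to compound 3 (0.27 log units; within the scatter). A second, different group also separates from hydrogen at this position, so the earlier gain is not tied to one substituent: an at least 11-fold lower number from compound 1 to compound 3 (1.05 log units; beyond the scatter). The value of compound 1 is a limit, and this step rests on it: the limit of > 100000 nM in this assay, at which 1 of the 3 values shown sits.

Open is whether the nitrile of 4-cyanobenzyl contributes, as plain benzyl is not among the compounds shown. Also open, going by these compounds, is whether an amine, a carboxylic acid or a longer alkyl chain on this nitrogen would move the number beyond the scatter.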